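Nitro in place of hydrogen on the methoxyphenyl group

The source may hold more compounds than are shown below. What is called first, only, known or untested is meant among the compounds shown, and "the series" means these compounds.

Measured compounds:
Compound 1 `O=C(O)CC/C=C\CC1COC(c2ccccc2Cl)OC1c1cccnc1`: 759 nM
Compound 2 `COc1ccc(OC(C)(C)C2OCC(C/C=C\CCC(=O)O)C(c3cccnc3)O2)cc1`: 302 nM

In a functional assay for inhibition, with Homo sapiens as the target (on this read-out lower numbers stand for tighter binding and higher numbers for weaker binding), compound 2 gives 302 nM, the lowest of the two numbers; compound 1 gives 759 nM, a gap beyond the scatter. Among the measured compounds shown here, no single-point step between measured compounds exists here, so the effect of adding a group to the methoxyphenyl ring is untested. Compound 3 `COc1ccc(OC(C)(C)C2OCC(C/C=C\CCC(=O)O)C(c3cccnc3)O2)c([N+](=O)[O-])c1` differs from compound 2 by nitro in place of hydrogen on an aromatic carbon. With nothing to anchor it, the expected step is small, likely within the scatter, in either direction. Compound 3 is therefore estimated at 300 nM, between 100 nM and 900 nM, an expected step of a 1.0-fold lower number from compound 2 to compound 3 (0.00 log units; within the scatter).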

Compound 3, dissociation constant: 6.17 nM
For compound 3 the middle estimate is 49-fold (1.69 log units) above the measured one; the whole stated range lies above it.
By their numbers in this assay, from the lowest: compound 3; then compound 2; then compound 1.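

In this assay the ring carbon ortho to a large group proves very sensitive: nitro in place of its hydrogen, which gives the 4-methoxy-2-nitrophenyl group, brings a 49-fold lower number from compound 2 to compound 3 (1.69 log units; beyond the scatter) from this one change. So three added heavy atoms at a single place can move the read-out strongly toward tighter binding, which the earlier compounds, with no single-place step between them, could not show. Nothing measured here says why the step is so large. As far as these compounds go, whether an amine or a nitrile on this same carbon would give a similar step remains open.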